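The compounds below may be only part of what the source reports. "The series", "measured", "known", "first", "only" and "open" are said of these compounds alone.

Measured so far:
- compound 1, `N#C[C@]1(O)[C@H](O)[C@@H](CO)O[C@@H](n2cc(F)c(O)nc2=O)[C@@H]1O`: 1900 nM
- compound 2, `N#C[C@H]1[C@@H](O)[C@H](n2cc(F)c(O)nc2=O)O[C@H](CO)[C@H]1O`: 550000 nM

In a functional assay on L1210 cells (Mus musculus) (a higher number here means a weaker inhibitor, a lower number a stronger inhibitor), compound 1 gives 1900 nM, whereas compound 2 gives 550000 nM, the higher of the two numbers by a margin well beyond the scatter of repeated runs; compound 2 therefore stands as the far weaker of the two in this assay, with compound 1 its only comparator. Among the measured compounds shown here, no single-point step between the two is available, as they differ in more than one place.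

Compound 3, `Cc1cn([C@@H]2O[C@H](CO)[C@@H](O)[C@@H](C#N)[C@H]2O)c(=O)nc1O`, is compound 2 with methyl in place of fluoro on an aromatic carbon, on an aromatic carbon of a six-membered aromatic ring with two nitrogens, ortho to a hydroxy group. For the measured compounds named here, nothing measured so far isolates this exchange, so the expected size of the step in this assay rests only on compound 2 sitting at a very weak level already. The expected step from compound 2 to compound 3 is a 1.3-fold higher number from compound 2 to compound 3 (0.10 log units; within the scatter), that is, nothing beyond the scatter, with a slight lean toward a higher number.

Compound 3 is therefore estimated at 700000 nM in this assay, in a range from 200000 nM to 2500000 nM, with a real chance that only a limit is reported.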

Compound 3, half-maximal inhibitory concentration: > 750000 nM
Compound 3: no number, only a limit; the forecaster's own chance of this, stated with the estimate: 50%; at least 1.0-fold (0.02 log units) between middle value and limit.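

In this assay, among the compounds shown here, compound 3 carries only a limit, > 750000 nM, so this position now has a first reading for an exchange that neither earlier compound could show. Methyl in place of fluoro on this aromatic carbon, ortho to a hydroxy group, reads as an at least 1.3-fold higher number from compound 2 to compound 3 (0.13 log units; that floor lies within the scatter), and since that is a floor, the exchange shows no gain in inhibition and gives no measured value on this core. From the compounds shown here alone, the true size of the step stays open because compound 3 has only a limit: the limit of > 750000 nM in this assay, at which 1 of the 3 values shown sits.

Still open, going by these compounds, is whether the same exchange reads differently on the core of compound 1, where compound 1 gives 1900 nM and a step in either direction could show as a number. Also open, on these data alone, is how hydrogen, chloro or an amine in place of fluoro on this aromatic carbon would read in this assay.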